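A few compounds are considered here, and "the series" means these few. Any claim that something is new, unique, unknown or untested is made for them only; others in the source may bear on it.

Measured compounds:
compound 1 `CCCCc1oc2ccccc2c1C(=O)c1ccc(OCC(=O)N2CCCC2)cc1`: 42400 nM
compound 2 `CCCCc1oc2ccccc2c1C(=O)c1ccc(OCC(=O)Nc2cccc(OC)c2)cc1`: 38500 nM

In a functional assay on MCF7 cells (Homo sapiens) for antiproliferative activity, read by MTT assay, with a stated time of 24 h (on this read-out higher numbers stand for weaker inhibition and lower numbers for stronger inhibition), compound 1 gives 42400 nM, the highest of the two numbers recorded, with compound 2 closest to it. Compound 2 differs from compound 1 only in the group on the carbonyl carbon, and the step of a 1.1-fold lower number from compound 1 to compound 2 (0.04 log units; within the scatter) is within the scatter, so the two values show no difference that can be trusted.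

Compound 3 `CCCCc1oc2ccccc2c1C(=O)c1ccc(OCCCC(=O)N2CCCCC2)cc1` has not yet been measured. It differs from compound 1 by 2-((piperidin-1-yl)carbonyl)ethyl in place of (pyrrolidin-1-yl)carbonyl on a saturated chain carbon bound to an oxygen on an aromatic ring. Among the compounds with values here, the only measured step, the one from compound 1 to compound 2, swapped the group on the carbonyl carbon and left the chain untouched; it moved the number by a size within the scatter. Within the data shown here, no measured pair covers a longer chain or a larger ring, so the step to compound 3 has no direct precedent here.

Given that the one known change around this part of the molecule produced nothing beyond the scatter, compound 3 is expected to come out near compound 1, at an estimated 40000 nM with a range from 15000 nM to 100000 nM. The expected step is therefore a 1.1-fold lower number from compound 1 to compound 3 (0.03 log units; within the scatter), meaning no change beyond the scatter.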

Compound 3, half-maximal inhibitory concentration: 33000 nM
Compound 3: middle estimate off by 1.2-fold (0.08 log units), on the high side; the range from low to high includes it.
By their numbers in this assay, from the lowest: compounds 3, 2 and 1 (each within the scatter of the next).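

Compound 3 changes two things at once on the saturated chain carbon bound to an oxygen on an aromatic ring: 2-((piperidin-1-yl)carbonyl)ethyl, with 10 heavy atoms, replaces (pyrrolidin-1-yl)carbonyl, with 7, and in this assay the comparison gives a 1.3-fold lower number from compound 1 to compound 3 (0.11 log units; within the scatter). Set against the amide with the aromatic (3-methoxyphenyl) group, the same position gives a 1.2-fold lower number from compound 2 to compound 3 (0.07 log units; within the scatter), so the three compounds cannot be placed in any order, and this position has now accepted a larger group with a six-membered ring as well as a change on the carbonyl carbon without a shift that can be trusted. No supporting measurement is available to say anything about the reason for this flat result.

As far as these compounds go, the chain and the ring changed together here, so their separate contributions stay unknown; 3-((pyrrolidin-1-yl)carbonyl)propyl or ((piperidin-1-yl)carbonyl)methyl would separate the two. From the compounds shown here alone, it also remains open whether a quite different end to the chain, such as a carboxylic acid or a free amine in place of the amide, would move the number beyond the scatter.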